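Fluorine on the Phenylpiperazine Ring of a Succinimide Amide

The compounds below may be only part of what the source reports. "The series", "measured", "known", "first", "only" and "open" are said of these compounds alone.

Measured so far:
compound 1, `Cc1cccc(N2CCN(C(=O)CN3C(=O)CC(C)(c4ccccc4)C3=O)CC2)c1`, gives 300 mg/kg
compound 2, `CC1(c2ccccc2)CC(=O)N(CC(=O)N2CCN(c3ccccc3)CC2)C1=O`, gives "not active" (no number reported)

Two compounds share a core in which a phenyl-substituted succinimide is joined through an acetamide to an arylpiperazine. In a functional assay on the whole organism (strain CD-1) with Mus musculus as the target, in the maximal electroshock model, with a stated time of 2 h (a lower number here means that less compound is needed, a higher number that more compound is needed for the effect), compound 1 reaches 300 mg/kg. Among the compounds with values here, compound 2 carries an unsubstituted phenyl on the piperazine, and in this assay compound 2 is reported as "not active" (no number reported), so no number stands for it; it can only be said that compound 1 has a dose at which it works and compound 2 does not, and no step between them has been computed.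

Compound 3, `CC1(c2ccccc2)CC(=O)N(CC(=O)N2CCN(c3ccc(F)cc3)CC2)C1=O`, is the next case. It differs from compound 2 by fluoro in place of hydrogen on an aromatic carbon, placed on an aromatic carbon of the six-membered aromatic ring of carbon only, para to a large group; seen one bond further out, phenyl becomes 4-fluorophenyl. Within the data shown here, with compound 2 giving no number, no step in this assay can be sized; the account expects either a dose close to that of compound 1 or again no activity. The minimum effective dose of compound 3 is estimated at 300 mg/kg, with a range from 100 mg/kg to 600 mg/kg.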

Compound 3, minimum effective dose: 100 mg/kg
The estimate for compound 3 lay 3.0-fold (0.48 log units) above the measured number; the measured number falls inside the stated range.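

In this assay, fluoro on an aromatic carbon para to a large group separates compound 3, which has a dose at which it works, from compound 2, which has no reported number, so this position can carry activity that the unsubstituted phenyl does not show; the step between these two cannot be read as a size. Set against 3-methylphenyl on the same amine nitrogen in a ring, 4-fluorophenyl gives a 3.0-fold lower number from compound 1 to compound 3 (0.48 log units; beyond the scatter), so these two substituted rings are not interchangeable in this model, although the step changes both the group and its place on the ring and cannot assign the gain to either alone. Nothing available explains why this fluoro substitution is followed by activity.

On these data alone, whether the activity belongs to fluoro itself or would also appear with another group at the same carbon stays open, and chloro, methoxy or methyl there would test that. Also open, as far as these compounds go, is whether fluoro keeps this dose on the other carbons of the ring, or whether a second fluoro on the same ring would shift it.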